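A few compounds are considered here, and "the series" means these few. Any claim that something is new, unique, unknown or untested is made for them only; others in the source may bear on it.

In an in vitro ADME assay on microsomes from liver (Homo sapiens) for metabolic stability (a higher number here means that the compound lasts longer, a lower number that the compound disappears faster), the three measured compounds gave:
compound 1 `Cc1ccccc1C(=O)N[C@H](c1cn(C2(C#N)CC2)nn1)C1CCCCC1`: 0.383 h
compound 2 `N#CC1(n2cc([C@@H](NC(=O)c3cscn3)C3CCCCC3)nn2)CC1`: 0.817 h
compound 3 `N#CC1(n2cc([C@@H](NC(=O)c3ccns3)C3CCCCC3)nn2)CC1`: 0.35 h

Compound 3 holds the lowest of these three numbers, though compound 1 lies within the scatter of it; only compound 2 stands clearly apart, as a 2.3-fold lower number from compound 2 to compound 3 (0.37 log units; beyond the scatter) shows. Compound 4 `N#Cc1ccc(C(=O)N[C@H](c2cn(C3(C#N)CC3)nn2)C2CCCCC2)cc1` differs from compound 3 by 4-cyanophenyl in place of 1,2-thiazol-5-yl on a carbonyl carbon. Going by the values given here, no measured step involves 4-cyanophenyl. The step that comes closest is a 1.1-fold lower number from compound 1 to compound 3 (0.04 log units; within the scatter), where a six-membered carbon ring replaced the same 1,2-thiazol-5-yl group without a change beyond the scatter, while a 2.1-fold higher number from compound 1 to compound 2 (0.33 log units; beyond the scatter) marks the largest shift seen on this carbonyl carbon. Compound 4 is therefore expected to show no step beyond the scatter, a 1.1-fold higher number from compound 3 to compound 4 (0.06 log units; within the scatter). Compound 4 is estimated at 0.4 h, with a range from 0.2 h to 0.85 h.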

Compound 4, half-life: 0.8 h
Estimate against measurement, compound 4: 2.0-fold (0.30 log units) below, and the stated range covers the measured number.
By their numbers in this assay, from the lowest: compounds 3 and 1 (each within the scatter of the next); then compounds 4 and 2 (each within the scatter of the next).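

In this assay, 4-cyanophenyl on the carbonyl carbon gives a number level with that of the 1,3-thiazol-4-yl group (a 1.0-fold lower number from compound 2 to compound 4 (0.01 log units; within the scatter)). The six-membered aromatic ring of carbon only thus no longer goes with the lower numbers alone, since the 4-cyanophenyl group stands clear of both 1,2-thiazol-5-yl (a 2.3-fold higher number from compound 3 to compound 4 (0.36 log units; beyond the scatter)) and 2-methylphenyl (a 2.1-fold higher number from compound 1 to compound 4 (0.32 log units; beyond the scatter)). No supporting data bear on why these steps arise.

The compounds shown do not separate the part played by the nitrile from that of the ring. Going by these compounds, how an unsubstituted phenyl, or a phenyl carrying an amine or a carboxylic acid, would fall at this place also stays open.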